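From 2-cyanophenyl to 4-cyanophenyl

The source may hold more compounds than are shown below. What is called first, only, known or untested is meant among the compounds shown, and "the series" means these compounds.

In a functional assay on HEK293 cells (Homo sapiens) for cytotoxicity (a higher number here means that more compound is tolerated, a lower number that less compound is tolerated), compound 1 `COc1ccc([C@H]2CC(=O)N(c3ccc(N)cc3)C2)cc1OC1CCCC1` gives > 10000 nM, which is a limit and not a number. Compound 2 `COc1ccc([C@H]2CC(=O)N(c3ccccc3C#N)C2)cc1OC1CCCC1` gives > 10000 nM, which is again only a limit. Going by the values given here, the one measured step is a step that the two limits leave unreadable from compound 1 to compound 2, so it offers no size to carry forward. The evidence consists of the limit of > 10000 nM in this assay, at which 2 of the 2 values shown sit.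

Compound 3 `COc1ccc([C@H]2CC(=O)N(c3ccc(C#N)cc3)C2)cc1OC1CCCC1` keeps the shared core and differs from compound 2 as follows: 4-cyanophenyl in place of 2-cyanophenyl on an amide-type nitrogen in a ring. In words, 4-cyanophenyl stands in place of 2-cyanophenyl on an amide-type nitrogen in a ring.

With compound 1 and compound 2 both resting on (the limit of > 10000 nM in this assay, at which 2 of the 2 values shown sit), no step beyond the scatter is expected in this assay, and no direction can be favoured. The expected move is a step that the limit leaves unreadable from compound 2 to compound 3. For compound 3 the estimate is 15000 nM, with an expected range from 6000 nM to 40000 nM.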

Compound 3, half-maximal cytotoxic concentration: > 10000 nM
Compound 3: only a limit was reported; the forecaster's own chance of this, stated with the estimate: 88%; the middle value does not contradict the limit.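

Compound 2 and compound 3 differ only in where the cyano group sits, yet neither step to compound 3, from compound 1 or from compound 2, can be read, as all three values are limits: the limit of > 10000 nM in this assay, at which 3 of the 3 values shown sit.

The compounds shown leave open whether 4-cyanophenyl, 2-cyanophenyl and 4-aminophenyl differ at all in this assay.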